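The source may report more compounds than this note shows. Statements on the series, on what has been measured and on what is new or still open speak of the compounds shown alone.

Of the compounds shown here, three have been measured in an assay on isolated protein for inhibition of retinal dehydrogenase 2 (Homo sapiens); a lower number here means a stronger inhibitor, a higher number a weaker inhibitor. Compound 1 `Cn1ncc2c(=O)n(-c3ccccc3)c(/C=C/c3cccc(F)c3)nc21` gives 440 nM, compound 2 `C#Cc1ccc(-n2c(SC(C)c3ccccc3)nc3c(cnn3C)c2=O)cc1` gives 800 nM, and compound 3 `Cn1ncc2c(=O)n(-c3ccccc3)c(COc3cccc(F)c3)nc21` gives 1770 nM. Compound 2 thus holds the second highest of the three numbers; its value and that of compound 1 sit within the usual scatter of each other, while the value of compound 3 lies beyond the scatter at a higher number. Compound 4 `CC(Sc1nc2c(cnn2C)c(=O)n1-c1ccc(CO)cc1)c1ccccc1` has not yet been measured. It differs from compound 2 in a single place: hydroxymethyl in place of ethynyl on an aromatic carbon. For the measured compounds named here, no measured pair shows this same change, so there is no direct guide to its effect. Without such a guide, the expected step of a 1.3-fold higher number from compound 2 to compound 4 (0.10 log units; within the scatter) is none beyond the scatter. Compound 4 is accordingly estimated at 1000 nM, within 400 nM to 2500 nM in this assay.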

Compound 4, half-maximal inhibitory concentration: 600 nM
For compound 4 the middle estimate is 1.7-fold (0.22 log units) above the measured one; the range from low to high includes it.
By their numbers in this assay, from the lowest: compounds 1, 4 and 2 (each within the scatter of the next); then compound 3.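

In this assay the change to hydroxymethyl reads a 1.3-fold lower number from compound 2 to compound 4 (0.12 log units; within the scatter), so 4-ethynylphenyl and 4-(hydroxymethyl)phenyl cannot be told apart here. For the compounds shown here, this is the first pair to show that this position tolerates a group with a hydrogen-bond donor and acceptor in place of one with neither, at least in this assay. No measurement available here explains this result. Going by these compounds, whether an amine or a carboxylic acid on the same aromatic carbon would move the number beyond the scatter remains open, as does the effect of a longer chain ending in hydroxyl.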